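The source may hold more compounds than are shown below. What is called first, only, known or untested is meant among the compounds shown, and "the series" means these compounds.

Measured compounds:
compound 1 `Cc1ccc(-c2nc(NO)c3cc(Cl)ccc3n2)cc1`: 12.7 ug/mL
compound 2 `Cc1ccc(-c2nc(NN)c3cc(Cl)ccc3n2)cc1`: 3.98 ug/mL
compound 3 `Cc1ccc(-c2nc(Sc3ncccc3[N+](=O)[O-])c3cc(Cl)ccc3n2)cc1`: 5.39 ug/mL

In a functional assay on HeLa cells (Homo sapiens) for antiproliferative activity, read by MTT assay, with a stated time of 48 h (on this read-out lower numbers stand for stronger inhibition and higher numbers for weaker inhibition), compound 1 gives 12.7 ug/mL, compound 2 gives 3.98 ug/mL and compound 3 gives 5.39 ug/mL. On these three numbers compound 3 stands second highest: against compound 2 the gap is within the scatter, while against compound 1 compound 3 shows a lower number beyond the scatter. For the measured compounds named here, the only measured single-point step, a 3.2-fold lower number from compound 1 to compound 2 (0.50 log units; beyond the scatter), concerns the nitrogen substituent of the shared core and not the sulfur.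

Compound 4 `Cc1ccc(-c2nc(SCCO)c3cc(Cl)ccc3n2)cc1` differs from compound 3 by 2-hydroxyethyl in place of 3-nitropyridin-2-yl on a sulfur. Going by the values given here, no measured step touches the group on the sulfur, so there is nothing that bears directly on this change; the one step known is of modest size and on another position. The expectation for compound 4 is therefore a step of at most modest size, more likely toward a higher number, as a 1.6-fold higher number from compound 3 to compound 4 (0.20 log units; within the scatter). Compound 4 is estimated at 8.5 ug/mL, within a range from 2.7 ug/mL to 27 ug/mL.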

Compound 4, half-maximal inhibitory concentration: 9.25 ug/mL
Compound 4: the middle estimate sits 1.1-fold (0.04 log units) below what was measured; measured number inside the range.
By their numbers in this assay, from the lowest: compounds 2, 3, 4 and 1 (each within the scatter of the next, the first and the last beyond it).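

In this assay, the change on the sulfur, 2-hydroxyethyl in place of 3-nitropyridin-2-yl, gives a step within the scatter (a 1.7-fold higher number from compound 3 to compound 4 (0.23 log units; within the scatter)), so the aromatic ring on this sulfur can give way to a small open chain with no difference that this read-out can resolve. Taken as a whole group on the aromatic carbon, (2-hydroxyethyl)sulfanyl is separated beyond the scatter from aminoamino (a 2.3-fold higher number from compound 2 to compound 4 (0.37 log units; beyond the scatter)), but stays within the scatter of hydroxyamino (a 1.4-fold lower number from compound 1 to compound 4 (0.14 log units; within the scatter)). Nothing available accounts for these steps. From the compounds shown here alone, with only these two groups on the sulfur, it remains open whether the hydroxyl of the chain plays any part. A longer chain, an amine or a carboxylic acid in its place, or a plain phenyl on the sulfur, could test this.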